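A Heteroaryl Swap on the Amide Nitrogen

The source may hold more compounds than are shown below. What is called first, only, known or untested is meant among the compounds shown, and "the series" means these compounds.

Compound 1 `O=C(O)CCNC(=O)c1cc(=O)c2ccccc2o1`: 0%
Compound 2 `O=C(Nc1nc[nH]n1)c1cc(=O)c2ccccc2o1`: 0%
Compound 3 `O=C(Nc1nccs1)c1cc(=O)c2ccccc2o1`: 15%

Three amides sharing one core have been tested in a functional assay on the whole organism for inhibition, with Rattus norvegicus as the target, with a stated time of 30 min, at a dose of 1 mg/kg by the intravenous route; a higher number here means more inhibition at the dose given (going by the name of the read-out), a lower number less inhibition. Compound 3 stands highest of the three numbers, with compound 1 and compound 2 each lying the same distance below it. The step of a number 15 percentage points higher from compound 1 to compound 3 (beyond the scatter) and the step of a number 15 percentage points higher from compound 2 to compound 3 (beyond the scatter) both point the same way, while no change at the digits printed from compound 1 to compound 2 (within the scatter) shows that the 2-carboxyethyl chain and the 1H-1,2,4-triazol-3-yl ring give the same read-out.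

Compound 4 `Cn1nnc(NC(=O)c2cc(=O)c3ccccc3o2)n1` is the next compound. Its difference from compound 3 is 2-methyl-2H-tetrazol-5-yl in place of 1,3-thiazol-2-yl on an amide-type nitrogen. Going by the values given here, the two steps that bear on this are the ones leading to compound 3, each of modest size, and the one from compound 1 to compound 2, which showed no change. Among the compounds with values here, since the nitrogen-rich 1H-1,2,4-triazol-3-yl ring of compound 2 gave 0%, and the incoming 2-methyl-2H-tetrazol-5-yl ring is also a nitrogen-rich five-membered ring, a drop of about the size of the earlier steps is expected for compound 4 in this assay. The estimate for compound 4 is 4%, with a range from 0% to 15%, which is an expected step of a number 11 percentage points lower from compound 3 to compound 4 (beyond the scatter).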

Compound 4, a percentage reported as inhibition, in the whole organism at one dose (the size of the read-out at that dose, not a potency): 25%
The estimate for compound 4 lay 21 percentage points below the measured number, and the stated range ends below it.
By their numbers in this assay, from the lowest: compounds 1 and 2 (each within the scatter of the next); then compounds 3 and 4 (each within the scatter of the next).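

Swapping the 1,3-thiazol-2-yl for the 2-methyl-2H-tetrazol-5-yl gives a number 10 percentage points higher from compound 3 to compound 4 (within the scatter) in this assay, so these two rings cannot be told apart by this read-out, even though the entering ring holds more nitrogen atoms and more hydrogen-bond acceptors. Against the other two amides, the same ring gives a number 25 percentage points higher from compound 2 to compound 4 (beyond the scatter) and a number 25 percentage points higher from compound 1 to compound 4 (beyond the scatter) as well, and the step from the 1H-1,2,4-triazol-3-yl shows that two azole rings on the amide-type nitrogen need not read alike. The nonzero read-out at this position is therefore now seen with two different rings, and a high nitrogen count in the ring does not by itself bring the number down to that of compound 2.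

Nothing measured here accounts for these differences. The compounds shown leave open whether the methyl group on the tetrazole matters, as an unmethylated 1H-tetrazol-5-yl ring would test, and whether a plain phenyl ring or a 2-aminoethyl chain on the same nitrogen would read like the two azoles at the top or like compound 1 and compound 2 at the bottom.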